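Iodo for Ethynyl on Two Related Nucleoside Cores

The compounds below may be only part of what the source reports. "The series", "measured", "known", "first", "only" and "open" are said of these compounds alone.

Measured so far in a functional assay on K562 cells (Homo sapiens), read by MTT assay, with a stated time of 72 h; on this read-out lower numbers stand for stronger inhibition and higher numbers for weaker inhibition:
compound 1 `C#Cc1cn([C@@H]2O[C@H](CO)[C@@H](O)[C@H]2O)c2ncnc(NC)c12`: 1380 nM
compound 2 `C#Cc1cn([C@@H]2O[C@H](CO)[C@@H](O)[C@H]2O)c2nc(C)nc(N)c12`: 3290 nM
compound 3 `Cc1nc(N)c2c(I)cn([C@@H]3O[C@H](CO)[C@@H](O)[C@H]3O)c2n1`: 1110 nM

Compound 2 and compound 3 share one core and differ in a single place: iodo in place of ethynyl on an aromatic carbon. That change produced a 3.0-fold lower number from compound 2 to compound 3 (0.47 log units; beyond the scatter). Compound 1 carries a different core; its difference from the core of compound 2 is not broken down here, the two having the same atoms joined differently. The values of compound 1 and compound 3 lie within the usual scatter of each other, whereas the gap between compound 1 and compound 2 lies beyond it.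

Compound 4 `CNc1ncnc2c1c(I)cn2[C@@H]1O[C@H](CO)[C@@H](O)[C@H]1O` has not yet been measured in this assay. It stands to compound 1 as compound 3 stands to compound 2: iodo in place of ethynyl on an aromatic carbon. The surroundings of the changed position read the same in both cases, so this is the same change. A step of a 2.5-fold lower number from compound 1 to compound 4 (0.40 log units; beyond the scatter) is expected, resting on the earlier step of a 3.0-fold lower number from compound 2 to compound 3 (0.47 log units; beyond the scatter), tempered by the unbroken-down difference between the two cores. Compound 4 is therefore estimated at 550 nM, within an expected range from 250 nM to 1400 nM.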

Compound 4, half-maximal inhibitory concentration: > 20000 nM
Compound 4 gave a limit, no number (the forecaster's own chance of this, stated with the estimate: 0%); middle value at least 36-fold (1.56 log units) from the limit.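

In this assay compound 4 gives > 20000 nM, which is a limit of the assay and not a number. Iodo in place of ethynyl on an aromatic carbon here gives an at least 14-fold higher number from compound 1 to compound 4 (1.16 log units; beyond the scatter), so the change does not carry over from one core to the other in this series: the same change on two cores in this assay, a 3.0-fold lower number (0.47 log units; beyond the scatter) from compound 2 to compound 3 and an at least 14-fold higher number (1.16 log units; beyond the scatter) from compound 1 to compound 4, at least 42-fold (1.63 log units) apart, beyond the scatter of two such steps. Going by these compounds alone, this rests on only two pairs, and as one of them ends at a limit, it shows that the step goes in opposite directions on the two cores, but not its full size on the core of compound 1 or what in the cores sets the two steps apart.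

The compounds shown leave open which feature of the two cores, which hold the same atoms joined differently, separates the two outcomes. They also leave open whether bromo or chloro on that aromatic carbon would follow compound 3 or compound 4 on either core.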